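The source may hold more compounds than are shown below. What is called first, only, known or untested is meant among the compounds shown, and "the series" means these compounds.

Compound 3 `Nc1cc(N)c2nc(-c3ccccc3)c(Oc3ccc(F)cc3)nc2c1` is the only one of the three measured compounds that gives a plain number: in a functional assay on COLO 205 cells (Homo sapiens) for inhibition, read by sulforhodamine B assay, with a stated time of 48 h (on this read-out lower numbers stand for higher toxicity in this test and higher numbers for lower toxicity in this test), compound 3 gives 66100 nM. Compound 1 `Nc1cc(N)c2nc(-c3ccccc3)c(NCc3ccc(F)cc3)nc2c1` in this assay reaches only the limit < 100000 nM. Compound 2 `COc1ccc(Sc2nc3cc(N)cc(N)c3nc2-c2ccccc2)cc1` in this assay likewise reaches only the limit < 100000 nM. Both therefore stand at the limit of < 100000 nM in this assay, at which 2 of the 3 values shown sit. Compound 4 `Nc1cc(N)c2nc(-c3ccccc3)c(Sc3ccc(F)cc3)nc2c1` differs from compound 3 by (4-fluorophenyl)sulfanyl in place of 4-fluorophenoxy on an aromatic carbon. The three measured steps, a step that the two limits leave unreadable from compound 1 to compound 2, a step that the limit leaves unreadable from compound 1 to compound 3 and a step that the limit leaves unreadable from compound 2 to compound 3, are all left unreadable by those limits, so they give no size for the exchange of the ring-linking atom. A step within the scatter is expected, a 1.1-fold lower number from compound 3 to compound 4 (0.04 log units; within the scatter). Compound 4 is estimated at 60000 nM, between 25000 nM and 100000 nM.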

Compound 4, concentration lethal to 50% of the cells: < 100000 nM
Compound 4 gave a limit, no number (the forecaster's own chance of this, stated with the estimate: 40%); the middle value does not contradict the limit.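

In this assay compound 4 gives only a limit, < 100000 nM, so its steps from compound 1, compound 2 and compound 3 cannot be read. Going by these compounds, how far (4-fluorophenyl)sulfanyl in place of 4-fluorophenoxy shifts the lethal concentration remains open.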